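From Methylsulfonyl to Methyl: An Expected Step

A few compounds are considered here, and "the series" means these few. Any claim that something is new, unique, unknown or untested is made for them only; others in the source may bear on it.

Compound 1 `O=C(Nc1cccc(CNc2nccnc2Cl)c1)NC1CCCC1`: 18400 nM
Compound 2 `O=C(Nc1ccc(C(F)(F)F)cc1)Nc1cccc(CNc2nccnc2Cl)c1`: 5050 nM
Compound 3 `CS(=O)(=O)c1ccc(NC(=O)Nc2cccc(CNc3nccnc3Cl)c2)cc1`: 15100 nM

These values come from a functional assay on HepG2 cells (Homo sapiens) for antiproliferative activity, read by MTT assay, with a stated time of 48 h; a higher number here means a weaker inhibitor, a lower number a stronger inhibitor. Compound 3 stands within the scatter of compound 1, and its number lies above that of compound 2. Compound 4 `Cc1ccc(NC(=O)Nc2cccc(CNc3nccnc3Cl)c2)cc1` differs from compound 3 by one change, methyl in place of methylsulfonyl on an aromatic carbon. One measured step involves the same methylsulfonyl group: a 3.0-fold higher number from compound 2 to compound 3 (0.48 log units; beyond the scatter). Within the data shown here, that modest step is the only guide, and removing methylsulfonyl is expected to reverse part of it. The expected step is a 1.7-fold lower number from compound 3 to compound 4 (0.22 log units; within the scatter), modest and towards a lower number. For compound 4 the estimated value is 9000 nM, with an expected range of 4000 nM to 20000 nM.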

Compound 4, half-maximal inhibitory concentration: 11500 nM
Estimate against measurement, compound 4: 1.3-fold (0.11 log units) below; low and high end bracket the measured number.
By their numbers in this assay, from the lowest: compound 2; then compounds 4, 3 and 1 (each within the scatter of the next).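

In this assay the exchange of methylsulfonyl for methyl on this aromatic carbon gives a 1.3-fold lower number from compound 3 to compound 4 (0.12 log units; within the scatter) and so does not separate the two groups. Trifluoromethyl stays apart from methyl with a 2.3-fold higher number from compound 2 to compound 4 (0.36 log units; beyond the scatter) as it does from methylsulfonyl, while 4-methylphenyl and cyclopentyl on the amide-type nitrogen are not separated by a 1.6-fold lower number from compound 1 to compound 4 (0.20 log units; within the scatter) in these compounds. Nothing measured here accounts for these steps. As far as these compounds go, whether a chlorine atom, an amine or a carboxylic acid on the same carbon would stand with trifluoromethyl or with methyl remains open.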